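Replacing an Arylamine with Pyrrolidine on a Shared Core

The source may report more compounds than this note shows. Statements on the series, on what has been measured and on what is new or still open speak of the compounds shown alone.

Three compounds share one core and differ only in the group attached to a double-bonded ring carbon. Compound 1 `COc1cccc(NC2=CC(=O)c3nc4n(c3C2=O)[C@H]2OC[C@@H](O)[C@H]2OC4)c1` carries a (3-methoxyphenyl)amino group; in a functional assay on MGC-803 cells (Homo sapiens) for inhibition, read by sulforhodamine B assay (on this read-out higher numbers stand for weaker inhibition and lower numbers for stronger inhibition), compound 1 gives 1780 nM. Compound 2 `O=C1C(Nc2ccc(Br)cc2)=CC(=O)c2c1nc1n2[C@H]2OC[C@@H](O)[C@H]2OC1` gives 2020 nM in this assay, and compound 3 `O=C1C(Nc2cccc(F)c2)=CC(=O)c2c1nc1n2[C@H]2OC[C@@H](O)[C@H]2OC1` gives 1470 nM. Compound 1 thus stands second highest of the three numbers, with compound 2 nearest and compound 3 furthest, and all three lie within the scatter of one another. Among the measured compounds shown here, the only measured step, a 1.4-fold lower number from compound 2 to compound 3 (0.14 log units; within the scatter), is within the scatter and so shows no dependable effect of exchanging one aryl group for another on the amine nitrogen.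

Compound 4 `O=C1C=C(N2CCCC2)C(=O)c2c1nc1n2[C@H]2OC[C@@H](O)[C@H]2OC1` differs from compound 1 in that (pyrrolidin-1-yl in place of (3-methoxyphenyl)amino on a double-bonded ring carbon). For the measured compounds named here, no measured step covers this change: compounds 1, 2 and 3 all keep an aromatic ring on an amine nitrogen with one hydrogen-bond donor, whereas compound 4 has a five-membered non-aromatic ring and no hydrogen-bond donor in that place. The step from compound 2 to compound 3 only shows that varying the aryl group left the number unchanged within the scatter. The expected step of a 1.4-fold higher number from compound 1 to compound 4 (0.15 log units; within the scatter) is therefore of uncertain direction and carries a wide range. Compound 4 is estimated to give 2500 nM in this assay, between 700 nM and 9000 nM.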

Compound 4, half-maximal inhibitory concentration: > 16000 nM
Compound 4: no number, only a limit; the forecaster's own chance of this, stated with the estimate: 10%; middle value at least 6.4-fold (0.80 log units) from the limit.
By their numbers in this assay, from the lowest: compounds 3, 1 and 2 (each within the scatter of the next). At a limit, above all of these: compound 4.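

In this assay, pyrrolidin-1-yl in place of (3-methoxyphenyl)amino on the double-bonded ring carbon gives an at least 8.9-fold higher number from compound 1 to compound 4 (0.95 log units; beyond the scatter), whereas exchanging one aryl group for another gave only a 1.4-fold lower number from compound 2 to compound 3 (0.14 log units; within the scatter). This shows that the group at this position does matter, which compounds 1, 2 and 3 alone could not show, as their values all lie within the scatter of one another. Compound 4 has no exact number here, only a limit of the assay: the limit of > 16000 nM in this assay, at which 1 of the 4 values shown sits.

This one change removes the aromatic ring and the hydrogen-bond donor together, so the compounds shown cannot say which of the two loss of inhibition goes with, or whether the change in the ring itself is what counts. A cyclopentylamino group, which keeps an amine hydrogen without an aromatic ring, and an N-methyl-N-phenylamino group, which keeps the aromatic ring without that hydrogen, would pull these two features apart on the shared core.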